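Butyl to cyclopropylmethyl on the ester of compound 2

This account rests on a few compounds, and the source may have more. Where it says the series, first, only, none or still open, it means among the compounds named here.

Measured compounds:
compound 1 `CCCCOC(=O)Cc1c(C(C)C)nc(CCCC)n(Cc2ccc(-c3ccccc3-c3noc(=O)[nH]3)cc2)c1=O`: 21.6%
compound 2 `CCCCOC(=O)Cc1c(C)nc(CCCC)n(Cc2ccc(-c3ccccc3-c3noc(=O)[nH]3)cc2)c1=O`: 10.2%

In an ADME assay on microsomes from liver (Mus musculus) for metabolic stability, with a stated time of 30 min (on this read-out lower numbers stand for a less stable compound and higher numbers for a more stable compound), compound 1 gives 21.6% and compound 2 gives 10.2%. Within the data shown here, compound 2 thus stands lowest of the two numbers known so far, its nearest neighbour being compound 1, and the single measured step, a number 11.4 percentage points lower from compound 1 to compound 2 (beyond the scatter), lies beyond the scatter.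

Compound 3 `CCCCc1nc(C)c(CC(=O)OCC2CC2)c(=O)n1Cc1ccc(-c2ccccc2-c2noc(=O)[nH]2)cc1` is derived from compound 2 by a change at the ester end of the molecule: cyclopropyl in place of propyl on a saturated chain carbon bound to an oxygen next to a carbonyl group. Among the measured compounds shown here, none of the measured steps touches this part of the structure; the only step known, a number 11.4 percentage points lower from compound 1 to compound 2 (beyond the scatter), concerns the methyl in place of isopropyl on an aromatic carbon and therefore gives no direct guidance on the ester chain. With nothing measured to bear on the change, the expectation for compound 3 in this assay is a step of no more than the scatter, in no preferred direction, which is what a number 1.8 percentage points higher from compound 2 to compound 3 (within the scatter) expresses. Compound 3 is accordingly estimated at 12%, within a range from 4% to 26%.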

Compound 3, percent of the compound remaining: 13%
Compound 3: the middle estimate sits 1 percentage points below what was measured; measured number inside the range.
By their numbers in this assay, from the lowest: compounds 2, 3 and 1 (each within the scatter of the next, the first and the last beyond it).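

In this assay the ester end of the molecule now has a measured step of its own, a number 2.8 percentage points higher from compound 2 to compound 3 (within the scatter) and so within the scatter. Cyclopropylmethyl on the ester thus gives a read-out that cannot be told apart from that of butyl, although it brings in a three-membered ring with the same number of heavy atoms. The only earlier step, a number 11.4 percentage points lower from compound 1 to compound 2 (beyond the scatter) at an aromatic carbon, lay beyond the scatter, so among the steps shown, only the change at the aromatic carbon separates two compounds, and no data available here explain either result.

From the compounds shown here alone, whether another group in place of butyl on the ester, such as a longer chain, a benzyl group or a dimethylamino-bearing chain, or a free carboxylic acid or an amide in place of the ester itself, would move the number beyond the scatter remains open. Also open, going by these compounds, is whether cyclopropylmethyl would give the same result with isopropyl on the aromatic carbon, as in compound 1, instead of the methyl of compound 2.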